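The source may hold more compounds than are shown below. What is called first, only, known or untested is meant among the compounds shown, and "the series" means these compounds.

Among the compounds with values here, compound 1 `CCCCOC(=O)NS(=O)(=O)c1sc(CC(C)C)cc1-c1ccc(CN2C(=O)CN(C)C2=O)cc1` is the weaker of the two measured members: in an assay on membranes from uterus for displacement of a labelled ligand from Angiotensin type II receptor (Sus scrofa), with a stated time of 1.5 h (on this read-out lower numbers stand for stronger inhibition and higher numbers for weaker inhibition), compound 1 gives 68.6 nM, the highest of the two numbers, and its nearest neighbour, compound 2 `CCCCOC(=O)NS(=O)(=O)c1sc(CC(C)C)cc1-c1ccc(Cc2nccs2)cc1`, gives 3.2 nM. Within the data shown here, the one measured step, a 21-fold lower number from compound 1 to compound 2 (1.33 log units; beyond the scatter), comes from a single exchange of the group on the saturated chain carbon bound to an aromatic carbon, the 3-methyl-2,5-dioxoimidazolidin-1-yl of compound 1 for the 1,3-thiazol-2-yl of compound 2.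

Compound 3 `CCCCOC(=O)NS(=O)(=O)c1sc(CC(C)C)cc1-c1ccc(Cn2cccn2)cc1` has not been measured. It differs from compound 1 in the same place: 1H-pyrazol-1-yl in place of 3-methyl-2,5-dioxoimidazolidin-1-yl on a saturated chain carbon bound to an aromatic carbon. Among the measured compounds shown here, the entering group, like the 1,3-thiazol-2-yl of compound 2, is a five-membered aromatic ring with two hetero atoms, so the step from compound 1 to compound 2 is the only direct guide, and it was large. For the measured compounds named here, a step of similar direction is expected, though not necessarily of the same size, since only one such exchange has been measured. For compound 3 the number in this assay is estimated at 8 nM, between 2 nM and 30 nM, which would mean an expected step of an 8.6-fold lower number from compound 1 to compound 3 (0.93 log units; beyond the scatter).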

Compound 3, inhibition constant: 2.3 nM
For compound 3 the middle estimate is 3.5-fold (0.54 log units) above the measured one; the measured number falls inside the stated range.
By their numbers in this assay, from the lowest: compounds 3 and 2 (each within the scatter of the next); then compound 1.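

In this assay, exchanging the 3-methyl-2,5-dioxoimidazolidin-1-yl for the 1H-pyrazol-1-yl on a saturated chain carbon bound to an aromatic carbon gives a 30-fold lower number from compound 1 to compound 3 (1.47 log units; beyond the scatter), so the large step is no longer tied to the 1,3-thiazol-2-yl alone and now holds for two different five-membered aromatic rings with 2 hetero atoms. Those two rings are not separated by this read-out: the step between them is a 1.4-fold lower number from compound 2 to compound 3 (0.14 log units; within the scatter), so the different ring atoms and the different point of attachment of the 1,3-thiazol-2-yl and the 1H-pyrazol-1-yl leave no readable mark at this place. No accompanying measurement bears on these steps, so they stand here as observations without an explanation.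

The group that leaves compound 1 differs from the 1H-pyrazol-1-yl at once in ring type, in its 2 double bonds outside aromatic rings and in heavy atoms, 8 against 5, so the compounds shown cannot say which of these differences carries the step. Also open, as far as these compounds go, is how a phenyl ring, which has no hetero atoms, or an open-chain group such as dimethylamino would read on the same chain carbon.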